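The source may hold more compounds than are shown below. What is called first, only, known or untested is meant among the compounds shown, and "the series" means these compounds.

Compound 1 `c1cncc(-c2nc3ccccc3n2C2CC2)c1` — an assay on V79 cells for inhibition of cytochrome P450 11B1, mitochondrial (Homo sapiens), read by HTRF, with a stated time of 1 h; a lower number here means a stronger inhibitor, a higher number a weaker inhibitor: > 8330 nM
Compound 2 `Fc1cccc2nc(-c3cccnc3)n(C3CC3)c12` — this assay : > 10000 nM

Both values shown are limits of the assay and not numbers. Compound 1 reaches only the limit > 8330 nM in this assay. Compound 2 likewise reaches only the limit > 10000 nM in this assay. For the measured compounds named here, the single measured step, fluoro in place of hydrogen on an aromatic carbon, a step that the two limits leave unreadable from compound 1 to compound 2, has no readable size because the limit of > 10000 nM in this assay, at which 1 of the 2 values shown sits, and the limit of > 8330 nM in this assay, at which 1 of the 2 values shown sits, cap both ends of it. Compound 1 therefore stands only at a limit, with no number against which another compound could be placed.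

Compound 3 `CS(=O)(=O)c1ccc2c(c1)nc(-c1cccnc1)n2C1CC1` differs from compound 1 by methylsulfonyl in place of hydrogen on an aromatic carbon. Going by the values given here, no measured step bears directly on this change, and the one step recorded gives no size at all. With nothing to move the expectation away from the limit at which compound 1 sits, the estimated step that the limit leaves unreadable from compound 1 to compound 3 is taken as none beyond the scatter. Compound 3 is therefore expected at about 10000 nM, within 2500 nM to 40000 nM, most likely reported again only as a limit of this assay.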

Compound 3, half-maximal inhibitory concentration: > 10000 nM
Compound 3: no number, only a limit; the forecaster's own chance of this, stated with the estimate: 70%; the middle value sits exactly at the limit.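

In this assay compound 3 gives > 10000 nM, which is a limit of the assay and not a number. No step from compound 1 to compound 3 can be read, because neither end of it is a number: the limit of > 10000 nM in this assay, at which 2 of the 3 values shown sit.

The compounds shown leave open how strongly any of them inhibits the enzyme, and whether fluoro or methylsulfonyl in place of hydrogen changes that at all.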